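Compound 3: 4-methoxybenzyl in place of 4-acetylphenyl

The source may hold more compounds than are shown below. What is called first, only, known or untested is meant among the compounds shown, and "the series" means these compounds.

In a functional assay on Bel-7402 cells (Homo sapiens) for cytotoxicity, read by MTT assay (on this read-out lower numbers stand for stronger inhibition and higher numbers for weaker inhibition), compound 1 (`CCn1cc(C(=O)Nc2ccc(C)c([N+](=O)[O-])c2)c(=O)c2cc(F)c(N3CCNC(C)C3)c(F)c21`) gives 29100 nM as its reading. Compound 2 (`CCn1cc(C(=O)Nc2ccc(C(C)=O)cc2)c(=O)c2cc(F)c(N3CCNC(C)C3)c(F)c21`) gives > 50000 nM in the same test, and that value is a limit of the assay and not a number. Compound 2 therefore stands at the limit of > 50000 nM in this assay, at which 1 of the 2 values shown sits, and has no exact place on the scale. The next structure, compound 3 (`CCn1cc(C(=O)NCc2ccc(OC)cc2)c(=O)c2cc(F)c(N3CCNC(C)C3)c(F)c21`), carries 4-methoxybenzyl in place of 4-acetylphenyl on an amide-type nitrogen. For the measured compounds named here, one measured step bears on this change, since it falls on the same nitrogen: an at least 1.7-fold higher number from compound 1 to compound 2 (0.23 log units; that floor lies within the scatter) is all that the pair shows, and no measured compound yet carries a benzyl group there. Going by the values given here, no step beyond the scatter is therefore expected in this assay, and any expected movement is a slight one towards lower numbers, resting on compound 1 at 29100 nM as the only exact reading so far. The estimated change is an at least 1.2-fold lower number from compound 2 to compound 3 (0.09 log units; that floor lies within the scatter) and it stays small. The estimate for compound 3 is 40000 nM with an expected range from 17000 nM to 70000 nM in this assay.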

Compound 3, half-maximal inhibitory concentration: 10300 nM
Estimate against measurement, compound 3: 3.9-fold (0.59 log units) above; the measured number lies below the stated range.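

In this assay, the amide-type nitrogen now gives an exact reading of a change beyond the scatter, which the first pair could not do: with 4-methoxybenzyl in place of 4-methyl-3-nitrophenyl there is a 2.8-fold lower number from compound 1 to compound 3 (0.45 log units; beyond the scatter). With 4-methoxybenzyl in place of 4-acetylphenyl, a swap in which the heavy atom count stays the same, there is an at least 4.8-fold lower number from compound 2 to compound 3 (0.68 log units; beyond the scatter), so this position can move the reading even when that count does not change. The reading of compound 2 is a limit of the assay and not a number, so this second step gives only a floor: the limit of > 50000 nM in this assay, at which 1 of the 3 values shown sits.

The compounds shown do not separate the one-carbon link of the benzyl group from the methoxy group, as compound 3 differs from compound 1 and compound 2 in both at once. On these data alone, an unsubstituted benzyl, a 4-methoxyphenyl or a longer chain such as 2-phenylethyl on the same nitrogen would bear on that question, and how far the lower numbers extend remains open.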